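Swapping the cyano on selenium for a methyl

This account rests on a few compounds, and the source may have more. Where it says the series, first, only, none or still open, it means among the compounds named here.

Compound 2 `COc1ccc(N(C)c2nc(C)nc3ccccc23)cc1[Se]C#N` carries a selenium-bound cyano group on its shared core. For the measured compounds named here, in a functional assay on LoVo cells (Homo sapiens) for inhibition, read by MTT assay, with a stated time of 48 h (on this read-out higher numbers stand for weaker inhibition and lower numbers for stronger inhibition), compound 2 gives 73 nM, the lowest of the two numbers so far. Its nearest neighbour, compound 1 `COc1ccc(N(C)c2nc(C)nc3ccccc23)cc1C(=O)OCCC[Se]C#N`, gives 854 nM in this assay, and the step of a 12-fold lower number from compound 1 to compound 2 (1.07 log units; beyond the scatter) comes from exchanging the longer ester-linked chain for the short selenocyanate group. Compound 3 `COc1ccc(N(C)c2nc(C)nc3ccccc23)cc1[Se]C` differs from compound 2 by methyl in place of cyano on a selenium. Going by the values given here, no measured step touches the cyano group itself; the only known step concerns a different part of the molecule, so it offers no direct guide. Since compound 2 sits at the strongest end of this assay, the expectation is that the number moves upward, by a moderate amount, as a 3.4-fold higher number from compound 2 to compound 3 (0.53 log units; beyond the scatter). Compound 3 is therefore estimated at 250 nM, within a range from 60 nM to 1200 nM.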

Compound 3, half-maximal inhibitory concentration: 3 nM
The estimate for compound 3 lay 83-fold (1.92 log units) above the measured number; measured number below the stated range.
By their numbers in this assay, from the lowest: compound 3; then compound 2; then compound 1.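

The group on selenium matters a great deal in this assay: with methyl in place of cyano, the change gives a 24-fold lower number from compound 2 to compound 3 (1.39 log units; beyond the scatter), so the cyano group is not needed for a low number on this core. For the compounds shown here, this is the first measured change made directly at this selenium, and it shows that a single carbon there is enough to give the lowest number of the three compounds. Set against the longer ester-linked chain, the short methyl-bearing selenium group gives a 280-fold lower number from compound 1 to compound 3 (2.45 log units; beyond the scatter), but no accompanying measurement offers an explanation for either step.

From the compounds shown here alone, it remains open whether an ethyl group, a longer chain or a phenyl ring on the selenium would keep the number this low. The compounds shown also cannot tell whether selenium itself matters, since a methylthio group, with sulfur in its place, is not among them.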